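Shifting the Nitro Group Along a Benzyl Ether

The source may report more compounds than this note shows. Statements on the series, on what has been measured and on what is new or still open speak of the compounds shown alone.

This account follows two measured compounds built on a shared core and one that awaits measurement, all compared in an assay on CHO cells for displacement of a labelled ligand from Alpha-1B adrenergic receptor (Homo sapiens); on this read-out lower numbers stand for stronger inhibition and higher numbers for weaker inhibition. Compound 1 `COc1cccc(OC)c1OCCNCCOc1ccccc1OCc1ccccc1Cl` gives 0.562 nM in this assay. Compound 2 `COc1cccc(OC)c1OCCNCCOc1ccccc1OCc1cccc([N+](=O)[O-])c1` gives 0.794 nM in this assay. Going by the values given here, the only measured step, a 1.4-fold higher number from compound 1 to compound 2 (0.15 log units; within the scatter), lies within the scatter, so on the two numbers in hand compound 2 and compound 1 stand side by side, with no order between them. Compound 3 `COc1cccc(OC)c1OCCNCCOc1ccccc1OCc1ccc([N+](=O)[O-])cc1` has not yet been measured. It differs from compound 2 by 4-nitrophenyl in place of 3-nitrophenyl on a saturated chain carbon bound to an oxygen on an aromatic ring. Among the compounds with values here, no measured step in this set moves a nitro group from one place to another on the same ring; the single step available, a 1.4-fold higher number from compound 1 to compound 2 (0.15 log units; within the scatter), exchanged one substituted phenyl for another and was itself within the scatter. On that basis no change beyond the scatter is expected for compound 3 in this assay, and the step of a 1.1-fold higher number from compound 2 to compound 3 (0.05 log units; within the scatter) is the estimate's meaning. Compound 3 is therefore expected to give 0.9 nM, within a range from 0.3 nM to 3 nM.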

Compound 3, inhibition constant: 0.398 nM
The estimate for compound 3 lay 2.3-fold (0.35 log units) above the measured number; the range from low to high includes it.
By their numbers in this assay, from the lowest: compounds 3, 1 and 2 (each within the scatter of the next).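

Going by these compounds alone, the step from 3-nitrophenyl to 4-nitrophenyl is the only comparison here in which the atoms stay the same and only their joining differs, and in this assay it reads as a 2.0-fold lower number from compound 2 to compound 3 (0.30 log units; within the scatter) at the edge of the scatter but still inside it. Exchanging 2-chlorophenyl for 4-nitrophenyl at the same place, on a saturated chain carbon bound to an oxygen on an aromatic ring, gives a 1.4-fold lower number from compound 1 to compound 3 (0.15 log units; within the scatter) in this read-out, so compounds 1, 2 and 3 all stand within the scatter of one another and this assay does not separate these three groups. No measurement is at hand that would explain how these groups compare.

The compounds shown leave open whether this place keeps the same standing when the nitro group gives way to an amine or a carboxylic acid on the ring, or when the phenyl ring is carried on a longer chain. They also leave open whether the unsubstituted benzyl group would stand with these three in this assay or apart from them.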